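Amidoxime addition on a cyclic sulfone scaffold

The compounds below may be only part of what the source reports. "The series", "measured", "known", "first", "only" and "open" are said of these compounds alone.

In an ADME assay on THP-1 cells (Homo sapiens) for cytotoxicity, read by flow cytometry, with a stated time of 72 h (a lower number here means a stronger inhibitor, a higher number a weaker inhibitor), compound 1 `N/C(=N\O)c1ccc(S(=O)(=O)CC(=O)c2ccccc2)cc1` gives > 125000 nM, which is a limit of the assay rather than a number. Compound 2 `N/C(=N\O)c1ccc(C(=O)CS(=O)(=O)c2ccc(/C(N)=N/O)cc2)cc1` likewise gives > 125000 nM in this assay, again a limit. The change between them, (a group of 4 heavy atoms (1 carbon, 2 nitrogen, 1 oxygen; no ring) in place of a hydrogen atom, on an aromatic carbon), therefore leaves a step that the two limits leave unreadable from compound 1 to compound 2, the two limits hiding its size. Among the measured compounds shown here, compound 3 `CC1(c2ccccc2)CC(S(=O)(=O)c2ccc(/C(N)=N/O)cc2)=C(c2ccccc2)O1` carries a different core, and how its core differs from that of compound 1 is not broken down here; in this assay compound 3 gives 54700 nM, the only real number among the three measured values. For the measured compounds named here, compound 4 `CC1(c2ccccc2)CC(S(=O)(=O)c2ccc(/C(N)=N/O)cc2)=C(c2ccc(/C(N)=N/O)cc2)O1` has not yet been measured and differs from compound 3 by a group of 4 heavy atoms (1 carbon, 2 nitrogen, 1 oxygen; no ring) in place of a hydrogen atom, on an aromatic carbon, the same change as the one from compound 1 to compound 2, made at the same kind of place. The step of a 1.3-fold higher number from compound 3 to compound 4 (0.11 log units; within the scatter) is expected to be small, since the measured step that the two limits leave unreadable from compound 1 to compound 2 stays unreadable because of the limit of > 125000 nM in this assay, at which 2 of the 3 values shown sit, and gives no sign of a strong effect. Compound 4 is thus estimated at 70000 nM, with a likely range from 25000 nM to 140000 nM.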

Compound 4, half-maximal inhibitory concentration: 99500 nM
For compound 4 the middle estimate is 1.4-fold (0.15 log units) below the measured one; the range from low to high includes it.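

In this assay, the amidoxime group in place of a hydrogen atom on an aromatic carbon gives a 1.8-fold higher number from compound 3 to compound 4 (0.26 log units; within the scatter), so on this core the change does not separate the two compounds. Whether the same holds on the core of compound 1 cannot be said, because the step from compound 1 to compound 2 cannot be read: the limit of > 125000 nM in this assay, at which 2 of the 4 values shown sit. The series therefore offers one readable pair, which shows a result within the scatter on a single core but gives no measured comparison of the change from one core to another.

The compounds shown leave open whether a different group at that aromatic carbon, such as a carboxylic acid, an amine or a nitrile, would give a value in this assay that stands apart from that of compound 3. They also leave open what happens when the amidoxime group shared by all four compounds is replaced by one of these groups.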